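From cyclohexylamino to pentyloxy on the shared core

The source may report more compounds than this note shows. Statements on the series, on what has been measured and on what is new or still open speak of the compounds shown alone.

Measured in an ADME assay on HFF cells (Homo sapiens) for cytotoxicity, with a stated time of 8 days; a higher number here means that more compound is tolerated, a lower number that less compound is tolerated:
compound 1 `CC(C)CSc1nc(N)nc2c1ncn2/C=C1/CC1(CO)CO`: > 300000 nM (a limit)
compound 2 `Nc1nc(NCc2ccccc2)c2ncn(/C=C3/CC3(CO)CO)c2n1`: > 300000 nM (a limit)
compound 3 `Nc1nc(NC2CCCCC2)c2ncn(/C=C3/CC3(CO)CO)c2n1`: > 300000 nM (a limit)

Compound 3 stands only as a limit, > 300000 nM. The other two compounds are also known only as limits, so no order can be read among the three.

The next compound is compound 4 `CCCCCOc1nc(N)nc2c1ncn2/C=C1/CC1(CO)CO`. The change is pentyloxy in place of cyclohexylamino on an aromatic carbon, next to the ring nitrogen.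

Three measured steps change the group on this aromatic carbon: a step that the two limits leave unreadable from compound 1 to compound 2, a step that the two limits leave unreadable from compound 1 to compound 3 and a step that the two limits leave unreadable from compound 2 to compound 3. None of them has a readable size, and none introduces pentyloxy, so they set no firm size for the coming step. The expectation in this assay rests on (the limit of > 300000 nM in this assay, at which 3 of the 3 values shown sit). No change beyond the scatter is expected, and a further limit is the likeliest report. The expected step is a number no higher from compound 3 to compound 4 (the limit leaves the size open). For compound 4 the estimate is 300000 nM, with an expected range from 150000 nM to 600000 nM.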

Compound 4, half-maximal cytotoxic concentration: 259000 nM
Estimate against measurement, compound 4: 1.2-fold (0.06 log units) above; the range from low to high includes it.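

In this assay, among the compounds shown here, compound 4 gives 259000 nM, the first value at this position on the shared core that is a number and not a limit. Set against the three earlier groups, pentyloxy gives an at least 1.1-fold lower number from compound 3 to compound 4 (0.06 log units; that floor lies within the scatter), an at least 1.1-fold lower number from compound 2 to compound 4 (0.06 log units; that floor lies within the scatter) and an at least 1.1-fold lower number from compound 1 to compound 4 (0.06 log units; that floor lies within the scatter). Each of these steps is only a floor resting on a limit, so the result shows that pentyloxy, with no ring and no hydrogen-bond donor, brings a number within the range of this read-out, but it fixes no firm size for the change from cyclohexylamino, benzylamino or isobutylsulfanyl.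

On these data alone, whether pentyloxy truly differs from these three groups by more than the scatter stays open, and the values shown cannot order them: the limit of > 300000 nM in this assay, at which 3 of the 4 values shown sit. Also open, as far as these compounds go, is how this assay would read with a longer alkoxy chain such as octyloxy, a shorter one such as ethoxy, or a carboxylic acid on this aromatic carbon, and so whether chain length matters here at all.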